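The source may hold more compounds than are shown below. What is called first, only, known or untested is meant among the compounds shown, and "the series" means these compounds.

Compounds measured in a functional assay on U-87MG ATCC cells for antiproliferative activity against U-87 MG (Homo sapiens), read by sulforhodamine B assay, with a stated time of 72 h; on this read-out lower numbers stand for stronger inhibition and higher numbers for weaker inhibition:

Compound 1, `COc1cc(/C=C/COC(C)=O)ccc1OC(C)=O`: 1060 nM
Compound 2, `CC[C@H](C)C(=O)Oc1ccc(/C=C/COC(C)=O)cc1OC`: 480 nM
Compound 3, `CCC(=O)OC/C=C/c1ccc(OC(=O)CC)c(OC)c1`: 28800 nM

Among these three numbers compound 1 stands second highest; its nearest neighbour is compound 2, and compound 3 lies far off with the highest number of the set. Compound 4, `CCCC(=O)OC/C=C/c1ccc(OC(C)=O)c(OC)c1`, has not yet been measured. It differs from compound 1 in a single place: ethyl in place of hydrogen on a saturated chain carbon bound to a carbonyl carbon.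

Going by the values given here, only one measured step bears on this change, and only loosely. The step of a 2.2-fold lower number from compound 1 to compound 2 (0.34 log units; beyond the scatter) enlarges the acyl group on the other ester of the shared core, the one on the ring oxygen, and gives a modestly lower number. Compound 3 carries a larger acyl group on both esters and shows a far higher number than compound 1. Among the compounds with values here, it differs from compound 1 in two places at once, so no single step can be drawn from it. Within the data shown here, the evidence therefore points in opposite directions for enlarging an ester, and the one clean step concerns a different ester.

Compound 4 is thus expected to give a number close to compound 1, with wide uncertainty: 1400 nM, between 450 nM and 6000 nM. This corresponds to an expected step of a 1.3-fold higher number from compound 1 to compound 4 (0.12 log units; within the scatter), which would lie within the scatter.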

Compound 4, half-maximal inhibitory concentration: 18500 nM
For compound 4 the middle estimate is 13-fold (1.12 log units) below the measured one; the measured number lies above the stated range.
By their numbers in this assay, from the lowest: compound 2; then compound 1; then compounds 4 and 3 (each within the scatter of the next).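

In this assay, going by these compounds alone, the change from acetyl to propylcarbonyl gives a 17-fold higher number from compound 1 to compound 4 (1.24 log units; beyond the scatter) and so shows that this ester, which no earlier compound had changed on its own, responds strongly to a longer acyl chain. The step of a 2.2-fold lower number from compound 1 to compound 2 (0.34 log units; beyond the scatter) on the other ester of the shared core is only modest and runs the other way, so the two esters of compound 1 do not respond alike to enlargement. Nothing measured here explains this difference.

One step cannot show whether the number climbs gradually or abruptly as the chain on this ester grows, or whether a longer chain such as pentyl would raise it further. The compounds also leave open how a branched sec-butyl group would behave on this ester, and whether an amide or a carboxylic acid could replace it.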